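Urea series: fluoro to methoxy change

This account rests on a few compounds, and the source may have more. Where it says the series, first, only, none or still open, it means among the compounds named here.

Measured so far:
compound 1 `CSc1cc(C)nc(SC)c1NC(=O)N(Cc1ccc(F)cc1)Cc1cccc(-c2cc[nH]n2)c1` — < 0.1 mg/kg
compound 2 `Cc1cc(C)c(NC(=O)N(Cc2ccccc2)Cc2cccc(-c3cc[nH]n3)c2)c(C)c1` — > 1 mg/kg

In a functional assay on the whole organism (plasma) with Rattus norvegicus as the target (on this read-out higher numbers stand for an effect only at larger amounts of compound and lower numbers for an effect already at smaller amounts), compound 1 gives < 0.1 mg/kg, which is a limit of the assay and not a number (the limit of < 0.1 mg/kg in this assay, at which 1 of the 2 values shown sits). Compound 2 gives > 1 mg/kg in this assay, likewise a limit rather than a measured number (the limit of > 1 mg/kg in this assay, at which 1 of the 2 values shown sits). Among the compounds with values here, compound 1 and compound 2 differ in several places at once, so no single step between them is set down; their two values show only that the pair sits at opposite limits.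

Compound 3 `COc1ccc(CN(Cc2cccc(-c3cc[nH]n3)c2)C(=O)Nc2c(SC)cc(C)nc2SC)cc1` is not yet measured in this assay. From compound 1 it changes as methoxy in place of fluoro on an aromatic carbon. Within the data shown here, no measured step covers this change, so no direction is known from the data. The step from compound 1 to compound 3 is expected to stay within the scatter, a step that the limit leaves unreadable from compound 1 to compound 3. Compound 3 is therefore expected near 0.08 mg/kg, in the range 0.02 mg/kg to 0.4 mg/kg, with a fair chance that only a limit is reported.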

Compound 3, dose for half-maximal effect: < 0.1 mg/kg
Compound 3 was reported as a limit; the forecaster's own chance of this, stated with the estimate: 50%; the middle value does not contradict the limit.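

In this assay compound 3 gives < 0.1 mg/kg, a limit and not a number. Within the data shown here, compound 1 likewise stands at a limit, < 0.1 mg/kg, so no step between compound 1 and compound 3 can be read. The compounds shown leave open whether methoxy in place of fluoro on an aromatic carbon changes this read-out at all.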